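Swapping a Methylsulfanyl Group for a Benzylseleno Group

The compounds below may be only part of what the source reports. "The series", "measured", "known", "first", "only" and "open" are said of these compounds alone.

Compound 1 `O=C(/N=C(/NC(=O)c1cc(-c2ccccc2)nc2ccccc12)[Se]Cc1ccccc1)c1cc(-c2ccccc2)nc2ccccc12` and compound 2 `CS/C(=N\C(=O)c1cc(-c2ccccc2)nc2ccccc12)NC(=O)c1cc(-c2ccccc2)nc2ccccc12` share one core, while compound 3 `CS/C(=N\C(=O)c1cnc2ccccc2c1)NC(=O)c1cnc2ccccc2c1` and compound 4 `O=C(/N=C(/NC(=O)c1cnc2ccccc2c1)[Se]Cc1ccccc1)c1cnc2ccccc2c1` share another; the difference between the two cores is not broken down here. In a functional assay on K562 cells (Homo sapiens) for cytotoxicity, read by MTT assay, with a stated time of 72 h (on this read-out lower numbers stand for stronger inhibition of growth and higher numbers for weaker inhibition of growth), compound 2 gives 34400 nM, and compound 1 gives 9060 nM. Compound 1 differs from compound 2 in one place: a group of 8 heavy atoms (7 carbon, 1 selenium; one six-membered aromatic ring of carbon only) in place of a group of 2 heavy atoms (1 carbon, 1 sulfur; no ring), on a carbon with a double bond to nitrogen. That change made a 3.8-fold lower number from compound 2 to compound 1 (0.58 log units; beyond the scatter), a shift beyond the usual scatter. In this assay compound 3 gives 65800 nM, the highest of the three measured numbers. Compound 4 carries the same change, on the same kind of carbon with the same neighbours: a group of 8 heavy atoms (7 carbon, 1 selenium; one six-membered aromatic ring of carbon only) in place of a group of 2 heavy atoms (1 carbon, 1 sulfur; no ring), on a carbon with a double bond to nitrogen. Compound 4 has not yet been measured in this assay. Because the measured step of a 3.8-fold lower number from compound 2 to compound 1 (0.58 log units; beyond the scatter) came on the other core, a step of similar size is expected here, a 3.7-fold lower number from compound 3 to compound 4 (0.56 log units; beyond the scatter). The expectation rests on a single measured pair, so its range is kept wide. Compound 4 is expected to give 18000 nM in this assay, with a likely range from 7000 nM to 45000 nM.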

Compound 4, concentration for 50% growth inhibition: 29300 nM
Beside the measured number, compound 4's estimate is 1.6-fold (0.21 log units) below it; low and high end bracket the measured number.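

On the second core the same swap gives a 2.2-fold lower number from compound 3 to compound 4 (0.35 log units; beyond the scatter), so in this assay the benzylseleno group goes with stronger growth inhibition than the methylsulfanyl group on both cores. The two steps point the same way, and the gap in their size is no larger than repeated measurements could produce: the same change on two cores in this assay, a 3.8-fold lower number (0.58 log units; beyond the scatter) from compound 2 to compound 1 and a 2.2-fold lower number (0.35 log units; beyond the scatter) from compound 3 to compound 4, 1.7-fold (0.23 log units) apart, within the scatter of two such steps. This shows that the change carried over from one core to the other in this assay, but two pairs cannot show that it would carry over to further cores, and they do not explain why the number falls.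

The compounds shown leave open which part of the change matters, the selenium or the added six-membered aromatic ring, since both arrive together; a methylseleno group and a benzylsulfanyl group would separate the two. Also open, as far as these compounds go, is how a longer chain or an amine in the same place would compare with these two groups.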